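Permeability of a peptide-linked thiazolidinedione: one ring swap

The source may hold more compounds than are shown below. What is called first, only, known or untested is meant among the compounds shown, and "the series" means these compounds.

Of the compounds shown here, two have been measured in an ADME assay for permeability, using PAMPA; on this read-out lower numbers stand for lower permeability and higher numbers for higher permeability. Compound 1, `CCCC[C@H](NC(=O)[C@H](CCCCN)NC(=O)[C@H](CCCNC(=N)N)NC(=O)c1ccc(/C=C2\SC(=O)N(C3CCCCC3)C2=O)cc1)C(N)=O`, carries a cyclohexyl group on the ring nitrogen of its five-membered sulfur-containing ring; in this assay compound 1 gives 1.69 10^-6 cm/s. Compound 2, `CCCC[C@H](NC(=O)[C@H](CCCCN)NC(=O)[C@H](CCCNC(=N)N)NC(=O)c1ccc(/C=C2\SC(=S)N(Cc3ccc(OC)cc3)C2=O)cc1)C(N)=O`, differs in more than one place and gives 0.6 10^-6 cm/s in this assay. Compound 1 therefore stands highest of the two numbers, and the gap to compound 2 lies beyond the usual scatter of the measurement.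

Compound 3, `CCCC[C@H](NC(=O)[C@H](CCCCN)NC(=O)[C@H](CCCNC(=N)N)NC(=O)c1ccc(/C=C2\SC(=O)N(Cc3ccc(F)cc3)C2=O)cc1)C(N)=O`, is the next compound to be measured. Its change from compound 1 is 4-fluorobenzyl in place of cyclohexyl on an amide-type nitrogen in a ring. For the measured compounds named here, no single-change step between measured compounds is available to anchor this move, so the expectation rests on the two measured values alone. Compound 3 is expected to give a number at or modestly below that of compound 1, with the step from compound 1 to compound 3 estimated as a 1.5-fold lower number from compound 1 to compound 3 (0.19 log units; within the scatter), a change that may well stay within the scatter. For compound 3 the expected value in this assay is 1.1 10^-6 cm/s, with a range from 0.5 10^-6 cm/s to 2.2 10^-6 cm/s.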

Compound 3, apparent permeability: 0.43 10^-6 cm/s
Compound 3: middle estimate off by 2.6-fold (0.41 log units), on the high side, outside the stated range (below it).
By their numbers in this assay, from the lowest: compounds 3 and 2 (each within the scatter of the next); then compound 1.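

For the compounds shown here, this pair is the first single-change comparison, and it shows that the group on the amide-type nitrogen in the ring matters in this assay: putting 4-fluorobenzyl in place of cyclohexyl gives a 3.9-fold lower number from compound 1 to compound 3 (0.59 log units; beyond the scatter). The two groups match in having no hydrogen-bond donors, no hydrogen-bond acceptors and no net charge, so these counts do not separate them; they differ in that cyclohexyl is a non-aromatic ring of carbon only, while 4-fluorobenzyl has an aromatic ring, a fluorine and more heavy atoms. Nothing available here accounts for the fall in the number.

Going by these compounds, with several features changing at once, this one pair cannot show which of them goes with the step, and it remains open whether a plain benzyl group or a straight hexyl chain on the same nitrogen would give a number closer to that of compound 1 or that of compound 3. Also open, on these data alone, is whether a step of similar size would appear if the same swap were made with other parts of the core changed.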